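This account rests on a few compounds, and the source may have more. Where it says the series, first, only, none or still open, it means among the compounds named here.

Measured so far in an ADME assay on microsomes from liver (Mus musculus) for metabolic stability; a lower number here means that the compound disappears faster, a higher number that the compound lasts longer:
Compound 1 `CC(C)C(Nc1nccs1)c1ccc(-c2ccc3cccc(F)c3c2)[nH]c1=O` gives 0.0733 h.
Compound 2 `CCC(CC)(c1nnc[nH]1)c1ccc(-c2ccc3cccc(F)c3c2)[nH]c1=O` gives 0.447 h.
Compound 3 `CCn1ncc2c(F)cc(-c3ccc(C(CC)(CC)c4nncn4C)c(=O)[nH]3)cc21` gives > 3 h, which is a limit of this assay and not a number.

Among the two numbers available, compound 1 stands lowest; the nearest number is that of compound 2, which lies beyond the scatter of this assay. Among the measured compounds shown here, the third value sits at the limit of > 3 h in this assay, at which 1 of the 3 values shown sits, so only two numbers can be compared.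

The step under consideration leads from compound 1 to compound 4 `Cc1c[nH]c(C(c2ccc(-c3ccc4cccc(F)c4c3)[nH]c2=O)C(C)C)n1`. The change is 4-methyl-1H-imidazol-2-yl in place of (1,3-thiazol-2-yl)amino on a saturated chain carbon bound to an aromatic carbon and a saturated chain carbon. Both the group that leaves and the group that enters carry one five-membered aromatic ring with 2 hetero atoms; the count of hydrogen-bond acceptors falls, the donor count is unchanged, and the saturated chain carbon bound to an aromatic carbon and a saturated chain carbon now bears the ring itself rather than an amino-linked ring.

For the measured compounds named here, no measured step of this kind exists, so the expectation rests on the spread between compound 1 and compound 2 alone. For compound 4 a rise in this assay of roughly a 2.5-fold higher number from compound 1 to compound 4 (0.39 log units; beyond the scatter) is expected, beyond the scatter but short of the value of compound 2. Compound 4 is therefore estimated at 0.18 h, within a range of 0.06 h to 0.6 h.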

Compound 4, half-life: < 0.0667 h
Compound 4 gave a limit, no number; the forecaster's own chance of this, stated with the estimate: 3%; middle value at least 2.6-fold (0.43 log units) away from the limit.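

In this assay compound 4 gives < 0.0667 h, which is a limit of this assay and not a number. The step reads an at least 1.0-fold lower number from compound 1 to compound 4 (0.04 log units; that floor lies within the scatter), so the floor of this step does not separate the two compounds beyond the scatter, and 4-methyl-1H-imidazol-2-yl in place of (1,3-thiazol-2-yl)amino brings no visible gain in half-life. This is the first direct reading at this saturated chain carbon: a ring borne by the carbon itself, rather than an amino-linked ring, leaves the value at the low end of this assay, where the reading stops at a limit: the limit of < 0.0667 h in this assay, at which 1 of the 4 values shown sits.

Going by these compounds, how far compound 4 actually lies from compound 1 stays open, and compound 2 and compound 3 differ from compound 1 in more than one place, so they give no reading of this position alone. Also open, on these data alone, is whether an imidazol-2-yl ring without the methyl, or a carboxylic acid, on this saturated chain carbon would give a number that can be told apart from compound 1 in this assay.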